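This account rests on a few compounds, and the source may have more. Where it says the series, first, only, none or still open, it means among the compounds named here.

In a functional assay (strain AB) with Danio rerio as the target, read by microscopy, with a stated time of 1 h (on this read-out higher numbers stand for an effect only at larger amounts of compound and lower numbers for an effect already at smaller amounts), compound 1 (`CCC1CCc2c(sc(NC(=O)Nc3ccc(Cl)cc3)c2C(N)=O)C1`) gives > 25000 nM, which is a limit of the assay and not a number. It is the only one of the three measured compounds without a number. Compound 4 (`C[N+](C)(C)C1CCc2c(sc(NC(=O)Nc3ccc(Cl)cc3)c2C(N)=O)C1`) changes the group on a saturated ring carbon: a group of 4 heavy atoms (3 carbon, 1 nitrogen; no ring) in place of a group of 2 heavy atoms (2 carbon; no ring), on a saturated ring carbon. Among the compounds with values here, no measured step starts from compound 1, so the evidence is indirect. Compound 2 (`CCN1CCc2c(sc(NC(=O)Nc3ccc(Cl)cc3)c2C(N)=O)C1`) and compound 3 (`NC(=O)c1c(NC(=O)Nc2ccc(Cl)cc2)sc2c1CCN(CC1CCC1)C2`) carry a nitrogen in the ring and give numbers, with compound 2 at 3120 nM and compound 3 at 1360 nM. Within the data shown here, the one measured step, a 2.3-fold lower number from compound 2 to compound 3 (0.36 log units; beyond the scatter), is modest and concerns a different change, so it says little about the size of this one. Compound 4 also carries a nitrogen, though in a group of net charge +1 on a ring carbon, so a large move to a lower number in this assay is expected, with real doubt. The expected step is an at least 6.2-fold lower number from compound 1 to compound 4 (0.79 log units; beyond the scatter). For compound 4 the estimate is 4000 nM, with an expected range of 800 nM to 25000 nM.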

Compound 4, half-maximal effective concentration: 5870 nM
Estimate against measurement, compound 4: 1.5-fold (0.17 log units) below; low and high end bracket the measured number.
By their numbers in this assay, from the lowest: compound 3; then compounds 2 and 4 (each within the scatter of the next). At a limit, above all of these: compound 1.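

Before this result, the saturated ring carbon was represented only by ethyl in compound 1, which stands at a limit of the assay and gives no number. Compound 4 now shows that, with a different group on this carbon, this assay can return a number: the group of 4 heavy atoms with net charge +1 in place of ethyl gives an at least 4.2-fold lower number from compound 1 to compound 4 (0.62 log units; beyond the scatter). This size is only a lower bound, since the step starts from a limit: the limit of > 25000 nM in this assay, at which 1 of the 4 values shown sits.

The compounds shown leave open which feature of the entering group goes with the step, as only ethyl and this group stand on that ring carbon. A dimethylamino group or a longer amine chain at the same place would help separate the contribution of the nitrogen from that of the net charge.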